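This account rests on a few compounds, and the source may have more. Where it says the series, first, only, none or still open, it means among the compounds named here.

In a functional assay on HeLa cells (Homo sapiens) for antiproliferative activity, read by MTT assay, with a stated time of 48 h (a higher number here means a weaker inhibitor of growth, a lower number a stronger inhibitor of growth), compound 1 `CCOc1cc(NC(=O)CCCCCCC(=O)Nc2ccccc2N)cc2c1OCC([N+](=O)[O-])=C2` gives > 20000 nM, which is a limit of the assay and not a number. Going by the values given here, compound 2 `CCOc1cc(NC(=O)CCCCCC(=O)Nc2ccccc2N)cc2c1OCC([N+](=O)[O-])=C2` gives 14900 nM, the only actual number so far, and it marks a weak inhibitor of growth. Among the compounds with values here, the one measured step, an at least 1.3-fold lower number from compound 1 to compound 2 (0.12 log units; that floor lies within the scatter), is no more than a floor within the scatter. The next compound is compound 3 `CCOc1cc(NC(=O)CCCCCNC(=O)CCCc2ccccc2)cc2c1OCC([N+](=O)[O-])=C2`. Its change is ((3-phenylpropyl)carbonyl)amino in place of (2-aminophenyl)carbamoyl on a saturated chain carbon, five bonds along the chain from a carbonyl carbon, with ((3-phenylpropyl)carbonyl)amino in place of (2-aminophenyl)carbamoyl on a saturated chain carbon, five bonds along the chain from a carbonyl carbon. Going by these compounds, the measured step offers only indirect guidance, since the (2-aminophenyl)carbamoyl group is present in both compound 1 and compound 2, and so the exchange itself is untested. With compound 2 already as weak as 14900 nM, a small move towards a higher number in this assay is expected, probably not beyond the scatter. The expected step is a 1.3-fold higher number from compound 2 to compound 3 (0.13 log units; within the scatter). For compound 3 the estimate is 20000 nM, with an expected range of 8000 nM to 50000 nM, and the assay may well report only a limit.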

Compound 3, concentration for 50% growth inhibition: 6740 nM
Estimate against measurement, compound 3: 3.0-fold (0.47 log units) above, and the stated range ends above it.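

In this assay, putting ((3-phenylpropyl)carbonyl)amino in place of (2-aminophenyl)carbamoyl on a saturated chain carbon, five bonds along the chain from a carbonyl carbon, gives a 2.2-fold lower number from compound 2 to compound 3 (0.34 log units; beyond the scatter), which shows that growth inhibition at this level does not depend on the (2-aminophenyl)carbamoyl group in these compounds. The comparison with the longer-chain compound points the same way, with an at least 2.9-fold lower number from compound 1 to compound 3 (0.47 log units; beyond the scatter). That size is only a floor, because compound 1 stands at a limit of the assay and not at a number: the limit of > 20000 nM in this assay, at which 1 of the 3 values shown sits.

The compounds shown leave open whether the lower number comes from the loss of the (2-aminophenyl)carbamoyl group or from the 3-phenylpropyl part that enters, and a plain acetyl amide, a free amine or a carboxylic acid at this place would separate those two readings. Also open is how a shorter or a longer chain would act with ((3-phenylpropyl)carbonyl)amino at its end, as the only chain step shown, the one between the two (2-aminophenyl)carbamoyl compounds, has no more than a floor within the scatter.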